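Amide to urea on a shared pyrazole-linked scaffold

The compounds below may be only part of what the source reports. "The series", "measured", "known", "first", "only" and "open" are said of these compounds alone.

Compound 1 `COc1cc(-c2nn(-c3cccc(NC(=O)c4cccc(C(F)(F)F)c4)c3)cc2-c2ccncc2)ccc1Cl` gives 978 nM in a functional assay on SK-MEL-5 cells (Homo sapiens) for inhibition, read by sulforhodamine B assay, with a stated time of 48 h (a lower number here means a stronger inhibitor of growth, a higher number a weaker inhibitor of growth), the highest of the three numbers recorded. Compound 2 `O=C(Nc1cccc(-n2cc(-c3ccncc3)c(-c3ccc(Cl)c(O)c3)n2)c1)Nc1cc(C(F)(F)F)cc(C(F)(F)F)c1` gives 600 nM and compound 3 `O=C(Nc1cccc(-n2cc(-c3ccncc3)c(-c3ccc(Cl)c(O)c3)n2)c1)Nc1ccc(Cl)c(C(F)(F)F)c1` gives 550 nM; both gaps to compound 1 lie within the scatter, so no ordering among the three can be claimed. Compound 4 `COc1cc(-c2nn(-c3cccc(NC(=O)Nc4ccc(Cl)c(Cl)c4)c3)cc2-c2ccncc2)ccc1Cl` has not been measured. It differs from compound 1 at one place: (3,4-dichlorophenyl)amino in place of 3-(trifluoromethyl)phenyl on a carbonyl carbon. Within the data shown here, no step between measured compounds isolates this change, and the two values of compounds 2 and 3 beside that of compound 1 offer no gap beyond the scatter. The step is therefore expected to be small, close to none, with a slight lean toward a lower number, so that a 1.4-fold lower number from compound 1 to compound 4 (0.15 log units; within the scatter) is estimated. Compound 4 is expected to give about 700 nM, between 250 nM and 2000 nM.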

Compound 4, concentration for 50% growth inhibition: 741 nM
For compound 4 the middle estimate is 1.1-fold (0.02 log units) below the measured one; low and high end bracket the measured number.
By their numbers in this assay, from the lowest: compounds 3, 2, 4 and 1 (each within the scatter of the next).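

The change from (3-(trifluoromethyl)phenyl)carbonyl to (3,4-dichlorophenyl)carbamoyl gives a 1.3-fold lower number from compound 1 to compound 4 (0.12 log units; within the scatter) in this assay. This is the only step shown that isolates a change at this place, and it shows that replacing the amide with a urea while also changing the ring substituents leaves the number within the scatter. No measurement bears on why this step is so small.

The step changes the linking group and the ring substituents together, so their separate contributions remain unresolved. As far as these compounds go, it also remains open how a non-aromatic group, such as a piperidine ring bound through its nitrogen to the carbonyl carbon, would behave here.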